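The source may report more compounds than this note shows. Statements on the series, on what has been measured and on what is new or still open speak of the compounds shown alone.

Measured so far:
compound 1, `COc1ccc(/C=N/NC(=O)CSc2nnnn2-c2cccc3ccccc23)cc1OC`: 191000 nM
compound 2, `COc1cc(/C=N/NC(=O)CSc2nnnn2-c2cccc3ccccc23)ccc1O`: > 287000 nM

In an ADME assay on MT4 cells (Homo sapiens) for cytotoxicity, read by MTT assay (on this read-out lower numbers stand for higher toxicity in this test and higher numbers for lower toxicity in this test), compound 1 gives 191000 nM. For compound 2 this assay reports only a limit, > 287000 nM, so compound 2 stands at the top of the numbers shown and its exact value is open. The next compound is compound 3, `O=C(CSc1nnnn1-c1cccc2ccccc12)N/N=C/c1ccc(O)cc1`. Its change from compound 2 is hydrogen in place of methoxy on an aromatic carbon, removing the methoxy of the 4-hydroxy-3-methoxyphenyl group to leave 4-hydroxyphenyl. Going by the values given here, the only measured step, an at least 1.5-fold higher number from compound 1 to compound 2 (0.17 log units; that floor lies within the scatter), also trims an oxygen substituent on that ring and moved the number up, though only as far as the limit of > 287000 nM in this assay, at which 1 of the 2 values shown sits, allows, so its true size is unknown. On that basis no step beyond the scatter is expected from compound 2 to compound 3, a number no higher from compound 2 to compound 3 (the limit leaves the size open). Compound 3 is estimated at 287000 nM, with a range from 140000 nM to 580000 nM, and a renewed limit is as likely as a number.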

Compound 3, half-maximal cytotoxic concentration: > 309000 nM
Compound 3 was reported as a limit (the forecaster's own chance of this, stated with the estimate: 55%); at least 1.0-fold (0.03 log units) between middle value and limit.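

In this assay compound 3, like compound 2, is reported only as a limit: the limit of > 309000 nM in this assay, at which 1 of the 3 values shown sits.

With a limit at both ends, the step from the 4-hydroxy-3-methoxyphenyl group to the 4-hydroxyphenyl group cannot be read. Setting 4-hydroxyphenyl in place of 3,4-dimethoxyphenyl gives an at least 1.6-fold higher number from compound 1 to compound 3 (0.20 log units; that floor lies within the scatter), so the new compound adds a second limit-bound hydroxy compound but no step shown to exceed the scatter; the methoxy on this ring is not needed for the read-out to stay at a limit.

On these data alone, how far compound 2 and compound 3 lie past their limits stays open, so the methoxy change has no size here. Also open, as far as these compounds go, is whether an amine or a carboxylic acid in place of the hydroxy group would bring the read-out down to a number.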